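The source may hold more compounds than are shown below. What is called first, only, known or untested is meant among the compounds shown, and "the series" means these compounds.

Working notes on the series.

Compound 1 `CCc1nnc2sc(-c3c[nH]nc3-c3ccc(Cl)cc3)nn12` and compound 2 `CCCc1nnc2sc(-c3c[nH]nc3-c3ccc(Cl)cc3)nn12` share a core; the difference between them is methyl in place of hydrogen on a saturated chain carbon, two bonds along the chain from an aromatic carbon. In a functional assay on the whole organism (strain Wistar) for inhibition, with Rattus norvegicus as the target, read by paw edema, with stated times of 30 min and 2.5 h, at a dose of 20 mg/kg by the intraperitoneal route (on this read-out higher numbers stand for more inhibition at the one dose given (going by the name of the read-out) and lower numbers for less inhibition), compound 1 gives 56.9%, and compound 2 gives 64.7%. The step of a number 7.8 percentage points higher from compound 1 to compound 2 (within the scatter) is small and is not to be read as a real rise.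

Compound 3 `CCc1nnc2sc(-c3c[nH]nc3-c3ccc(Cl)cc3Cl)nn12` carries a second core, which differs from the core of compound 1 by chloro in place of hydrogen on an aromatic carbon. In this assay compound 3 gives 25.5%, the lowest of the three numbers, and the step of a number 31.4 percentage points lower from compound 1 to compound 3 (beyond the scatter) is beyond the scatter.

Compound 4 `CCCc1nnc2sc(-c3c[nH]nc3-c3ccc(Cl)cc3Cl)nn12` is not yet measured. It stands to compound 3 as compound 2 stands to compound 1: the change is methyl in place of hydrogen on a saturated chain carbon, two bonds along the chain from an aromatic carbon, the same change in the same place, only made on the core of compound 3 rather than the core of compound 1. This change has been seen once so far, as the step of a number 7.8 percentage points higher from compound 1 to compound 2 (within the scatter), which stayed within the scatter. Whether the same change behaves alike on the core of compound 3 cannot be checked with the compounds at hand; the expectation below rests only on that one earlier step.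

For compound 4 a step of about a number 5.5 percentage points higher from compound 3 to compound 4 (within the scatter) in this assay is expected, because the earlier step of a number 7.8 percentage points higher from compound 1 to compound 2 (within the scatter) was small. Compound 4 is therefore estimated at 31% in this assay, with a likely range from 18% to 45%.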

Compound 4, a percentage reported as inhibition, in the whole organism at one dose (the size of the read-out at that dose, not a potency): 23.5%
The estimate for compound 4 lay 7.5 percentage points above the measured number, and the stated range covers the measured number.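

In this assay, methyl in place of hydrogen on a saturated chain carbon gives a number 2 percentage points lower from compound 3 to compound 4 (within the scatter) on the core of compound 3, so on neither core does the change give a step beyond the scatter, and the two steps agree: the same change on two cores in this assay, a number 7.8 percentage points higher (within the scatter) from compound 1 to compound 2 and a number 2 percentage points lower (within the scatter) from compound 3 to compound 4, 9.8 percentage points apart, within the scatter of two such steps. Chloro in place of hydrogen on an aromatic carbon, read on the propyl compounds, gives a number 41.2 percentage points lower from compound 2 to compound 4 (beyond the scatter) and so lowers the number on both cores, again with agreement between the two steps: the same change on two cores in this assay, a number 31.4 percentage points lower (beyond the scatter) from compound 1 to compound 3 and a number 41.2 percentage points lower (beyond the scatter) from compound 2 to compound 4, 9.8 percentage points apart, within the scatter of two such steps. Within these four compounds, each change therefore carries from one core to the other, but this rests on one pair of steps per change at a single dose and does not show that the steps are identical or that either change would behave alike on any further core.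

Left open is whether a longer chain such as butyl, or a branched chain such as isopropyl, would also leave the number within the scatter of the ethyl and propyl compounds. From the compounds shown here alone, it is equally open whether fluoro, methyl or methoxy in place of the added chloro would bring a drop of similar size.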